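Swapping the aryl group on the carbonyl of compound 3

A few compounds are considered here, and "the series" means these few. Any claim that something is new, unique, unknown or untested is made for them only; others in the source may bear on it.

Measured compounds:
Compound 1 `CCCCCCOc1ccc(C(=O)/C=C/c2c(/C=C/c3ccc(OC)cc3)cc(OC)cc2OC)cc1`: 8.4 ug/mL
Compound 2 `COc1ccc(/C=C/c2cc(OC)cc(OC)c2/C=C/C(=O)c2ccc(Cl)c(Cl)c2)cc1`: 5.9 ug/mL
Compound 3 `COc1ccc(/C=C/c2cc(OC)cc(OC)c2/C=C/C(=O)c2ccc(C)c(C)c2)cc1`: 0.1 ug/mL

In a functional assay on A549 cells (Homo sapiens) for antiproliferative activity, read by MTT assay, with a stated time of 48 h (a lower number here means a stronger inhibitor, a higher number a weaker inhibitor), compound 3 gives the lowest number of the three, and the step of a 59-fold lower number from compound 2 to compound 3 (1.77 log units; beyond the scatter) shows how strongly the aryl group on the carbonyl carbon alters the result. Compound 4 `CCN(CC)c1ccc(C(=O)/C=C/c2c(/C=C/c3ccc(OC)cc3)cc(OC)cc2OC)cc1` differs from compound 3 only there: 4-(diethylamino)phenyl in place of 3,4-dimethylphenyl on a carbonyl carbon. Going by the values given here, no measured step covers this exact exchange; the one step that does touch this position was large, and compound 1, which carries a different para-substituted aryl at the same place, gives 8.4 ug/mL. The expected step of a 25-fold higher number from compound 3 to compound 4 (1.40 log units; beyond the scatter) is therefore an increase, with wide uncertainty. Compound 4 is estimated at 2.5 ug/mL, between 0.2 ug/mL and 25 ug/mL.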

Compound 4, half-maximal inhibitory concentration: 5.4 ug/mL
Beside the measured number, compound 4's estimate is 2.2-fold (0.33 log units) below it, within the range that was stated.
By their numbers in this assay, from the lowest: compound 3; then compounds 4, 2 and 1 (each within the scatter of the next).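

In this assay, the step of a 54-fold higher number from compound 3 to compound 4 (1.73 log units; beyond the scatter) is a second large one at this carbonyl carbon, so the low number of compound 3 is lost with 4-(diethylamino)phenyl as well as with 3,4-dichlorophenyl. The steps of a 1.1-fold lower number from compound 2 to compound 4 (0.04 log units; within the scatter) and a 1.6-fold lower number from compound 1 to compound 4 (0.19 log units; within the scatter) show no readable difference among these groups. No supporting measurement accompanies this result.

On these data alone, it remains open whether the low number of compound 3 needs both methyl groups, or whether a phenyl with a single methyl, or with two ethyl groups, would keep it.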